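Swapping the ring on the amine of compound 2

A few compounds are considered here, and "the series" means these few. Any claim that something is new, unique, unknown or untested is made for them only; others in the source may bear on it.

Measured so far:
- compound 1, `c1ccc2c(c1)CCC(CNCCCNC1=NCCCC1)O2`: 3.98 nM
- compound 2, `c1ccc2c(c1)CCC(CNCCCNc1cnccn1)O2`: 10 nM

In an assay on isolated protein (Bos taurus) with 5-hydroxytryptamine receptor 1D (Homo sapiens) as the target (on this read-out higher numbers stand for weaker inhibition and lower numbers for stronger inhibition), compound 2 gives the higher of the two numbers, with compound 1 giving a lower number by a 2.5-fold higher number from compound 1 to compound 2 (0.40 log units; beyond the scatter). Compound 3, `O=C1CCCN=C(NCCCNCC2CCc3ccccc3O2)N1`, has not been measured. It differs from compound 2 by a group of 8 heavy atoms (5 carbon, 2 nitrogen, 1 oxygen; one seven-membered non-aromatic ring with 2 hetero atoms) in place of a group of 6 heavy atoms (4 carbon, 2 nitrogen; one six-membered aromatic ring with 2 hetero atoms), on an amine nitrogen. Within the data shown here, the only step that bears on this is the one from the cyclic, non-aromatic group of compound 1 to the aromatic pyrazin-2-yl of compound 2, which raised the number by a 2.5-fold higher number from compound 1 to compound 2 (0.40 log units; beyond the scatter). Moving back from the aromatic ring to a non-aromatic one might therefore recover some of that loss, though the new seven-membered ring is not the ring of compound 1, so the expected change in this assay is a small lowering, a 1.7-fold lower number from compound 2 to compound 3 (0.22 log units; within the scatter), close to the scatter. For compound 3 the estimated value is 6 nM, within a range of 1.5 nM to 25 nM.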

Compound 3, half-maximal inhibitory concentration: 158 nM
Estimate against measurement, compound 3: 26-fold (1.42 log units) below, and the stated range ends below it.
By their numbers in this assay, from the lowest: compound 1; then compound 2; then compound 3.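

In this assay, among these compounds, the group on this amine nitrogen matters far more than the first pair of compounds suggested: the number climbs steeply from the pyrazin-2-yl compound (a 16-fold higher number from compound 2 to compound 3 (1.20 log units; beyond the scatter)), and further still from the six-membered non-aromatic ring (a 40-fold higher number from compound 1 to compound 3 (1.60 log units; beyond the scatter)). Having a non-aromatic ring here is therefore not enough on its own, since compound 1 and compound 3 both carry one yet give the lowest and highest numbers of the three. Nothing available explains this difference.

The compounds shown leave open whether the seven-membered ring size or the ring's oxygen accounts for the change, which a seven-membered ring without that oxygen could separate. They also leave open how a plain phenyl or a pyridin-2-yl on this nitrogen would compare with pyrazin-2-yl.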